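The source may report more compounds than this note shows. Statements on the series, on what has been measured and on what is new or still open speak of the compounds shown alone.

Series sharing the core of compound 1 `COc1ccc(-c2cc3ccccc3nc2/C=C/C(=O)c2ccc(OC)c(OC)c2)cc1`, varied at the group on the carbonyl carbon. In a functional assay on MDA-MB-231 cells (Homo sapiens) for antiproliferative activity, read by XTT assay, with a stated time of 72 h (on this read-out higher numbers stand for weaker inhibition and lower numbers for stronger inhibition), compound 1 gives 4790 nM. Compound 2 `COc1ccc(-c2cc3ccccc3nc2/C=C/C(=O)c2ccc([N+](=O)[O-])cc2)cc1` gives 840 nM in this assay, and compound 3 `COc1ccc(-c2cc3ccccc3nc2/C=C/C(=O)c2ccco2)cc1` gives 630 nM. Compound 3 holds the lowest number shown: the steps of a 7.6-fold lower number from compound 1 to compound 3 (0.88 log units; beyond the scatter) and a 5.7-fold lower number from compound 1 to compound 2 (0.76 log units; beyond the scatter) lie beyond the scatter, whereas a 1.3-fold lower number from compound 2 to compound 3 (0.12 log units; within the scatter) does not, so compound 3 and compound 2 cannot be separated. Compound 4 `COc1ccc(-c2cc3ccccc3nc2/C=C/C(=O)c2sccc2N)cc1` carries 3-aminothiophen-2-yl in place of furan-2-yl on a carbonyl carbon. For the measured compounds named here, no measured step tests this exchange; the nearest, a 1.3-fold lower number from compound 2 to compound 3 (0.12 log units; within the scatter), replaced one group on the carbonyl carbon with another and stayed within the scatter. A step of similar size is therefore expected, a 1.0-fold higher number from compound 3 to compound 4 (0.01 log units; within the scatter), with no direction beyond the scatter. Compound 4 is estimated at 650 nM, range 200 nM to 2000 nM.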

Compound 4, half-maximal inhibitory concentration: > 10000 nM
Compound 4: no number, only a limit; the forecaster's own chance of this, stated with the estimate: 5%; at least 15-fold (1.18 log units) between middle value and limit.
By their numbers in this assay, from the lowest: compounds 3 and 2 (each within the scatter of the next); then compound 1. At a limit, above all of these: compound 4.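

Compound 4 gives a limit and not a number in this assay: the limit of > 10000 nM in this assay, at which 1 of the 4 values shown sits.

One five-membered aromatic ring in place of another gives an at least 15-fold higher number from compound 3 to compound 4 (1.20 log units; beyond the scatter) and so the ring size alone does not hold the activity at this position. The other two groups on the carbonyl carbon read the same way, with an at least 11-fold higher number from compound 2 to compound 4 (1.07 log units; beyond the scatter) and an at least 2.0-fold higher number from compound 1 to compound 4 (0.31 log units; beyond the scatter) both beyond the scatter.

The exchange alters the ring hetero atom and adds an amine together, and the compounds shown do not say which of the two matters. Plain thiophen-2-yl, without the amine, would separate them.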